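From phenyl to 4-methylphenyl in the series

The compounds below may be only part of what the source reports. "The series", "measured", "known", "first", "only" and "open" are said of these compounds alone.

For the measured compounds named here, only two compounds have been read so far in a functional assay on SW982 cells (Homo sapiens) for inhibition, read by MTT assay, with a stated time of 72 h; on this read-out higher numbers stand for weaker inhibition and lower numbers for stronger inhibition. In this assay compound 1 (`COc1cc(OC)c(-c2cc(=O)c3ccc(O)cc3o2)cc1OC`) gives > 150000 nM, which is a limit and not a number. Compound 2 (`COc1cc(OC)c(OC)cc1/C=C/C(=O)c1ccccc1`) gives > 150000 nM, which is likewise a limit and not a number. Compound 2 therefore has no numerical standing in the series and sits at the limit of > 150000 nM in this assay, at which 2 of the 2 values shown sit.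

Compound 3 (`COc1cc(OC)c(OC)cc1/C=C/C(=O)c1ccc(C)cc1`) is compound 2 with methyl in place of hydrogen on an aromatic carbon, para to a large group: methyl in place of hydrogen on an aromatic carbon. Going by the values given here, no measured pair carries this change, so its size cannot be read from the data. The step expected in this assay is a number no higher from compound 2 to compound 3 (the limit leaves the size open), with nothing expected beyond the scatter and no direction favoured. This expectation rests on compound 2 at > 150000 nM, a limit. For compound 3 the estimate is 150000 nM, with an expected range of 60000 nM to 300000 nM.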

Compound 3, half-maximal inhibitory concentration: 81100 nM
The estimate for compound 3 lay 1.8-fold (0.27 log units) above the measured number; the measured number falls inside the stated range.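

For the compounds shown here, compound 3 at 81100 nM in this assay holds the only one of the three values shown that is a number and not a limit, so this change on the aromatic carbon para to a large group gives the series its first numerical reference point. Methyl in place of hydrogen here goes with an at least 1.8-fold lower number from compound 2 to compound 3 (0.26 log units; that floor lies within the scatter) and is the first step that can be read in the series, yet its floor alone does not show an effect beyond the scatter. Compound 2 carries only a limit, so the step has a floor and no upper end, and its true size stays unknown because of that limit: the limit of > 150000 nM in this assay, at which 2 of the 3 values shown sit.

Whether the gain, if real, belongs to methyl alone stays open: the compounds shown do not tell how a chlorine atom, an amine, a carboxylic acid or a longer chain would read at this same place. Nor do they tell whether methyl would read the same on another carbon of this ring, and compound 1 differs from compound 3 in more than one place and so offers no comparison for this change.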